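Tetrabromo core with a chlorophenyl carbinol: compound 3

The source may hold more compounds than are shown below. What is called first, only, known or untested is meant among the compounds shown, and "the series" means these compounds.

Measured so far:
compound 1, `OC(CCn1nc2c(Br)c(Br)c(Br)c(Br)c2n1)c1cccc(Cl)c1`, 110%
compound 2, `CC(O)CCn1nc2c(Br)c(Br)c(Br)c(Br)c2n1`, 106%

Both compounds were tested in a functional assay on CCRF-CEM cells (Homo sapiens) for antiproliferative activity, read by MTT assay, with a stated time of 24 h, tested at 12.5 uM; on this read-out higher numbers stand for a weaker effect at the one concentration tested and lower numbers for a stronger effect. Compound 2 gives the lower of the two numbers, but its nearest neighbour, compound 1, lies within the scatter of it, so the two cannot be told apart on these data.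

Compound 3, `OC(CCn1nc2c(Br)c(Br)c(Br)c(Br)c2n1)c1ccc(Cl)cc1`, is not yet measured. It differs from compound 2 in one place: 4-chlorophenyl in place of methyl on a saturated chain carbon bound to an oxygen on a saturated carbon and a saturated chain carbon.

For the measured compounds named here, one measured step bears on this change. It runs the other way, exchanging a chlorophenyl for the methyl at the same place: a number 4 percentage points lower from compound 1 to compound 2 (within the scatter). That step stayed within the scatter, so replacing the methyl by a chlorophenyl carrying its chlorine at a different position is not expected to move this assay beyond the scatter either; the step of a number 2 percentage points higher from compound 2 to compound 3 (within the scatter) is expected to be small and in no reliable direction.

Compound 3 is therefore estimated at 108%, with a range from 95% to 120%.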

Compound 3, a percentage reported as activity, at one concentration (the size of the read-out at that concentration, not a potency): 105%
For compound 3 the middle estimate is 3 percentage points above the measured one; measured number inside the range.
By their numbers in this assay, from the lowest: compounds 3, 2 and 1 (each within the scatter of the next).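

In this assay, 4-chlorophenyl in place of methyl on the saturated chain carbon bound to the oxygen gives a number 1 percentage points lower from compound 2 to compound 3 (within the scatter), so this second chlorophenyl compound also fails to separate from the methyl compound. The comparison of the two chlorophenyl groups at this same place gives a number 5 percentage points lower from compound 1 to compound 3 (within the scatter), which shows that the 4-chlorophenyl and 3-chlorophenyl groups cannot be told apart on this read-out. Across these three compounds, then, neither the exchange of methyl for a chlorophenyl group nor the place of the chlorine on that ring produces a step beyond the scatter. Nothing in the data shown accounts for this result.

The compounds shown leave open whether an amine or a carboxylic acid at this carbon, or a longer chain in place of the present one, would move the number beyond the scatter. They also leave open whether a carbonyl in place of the carbon bearing the oxygen would give a read-out distinct from those of compound 1, compound 2 and compound 3.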